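A few compounds are considered here, and "the series" means these few. Any claim that something is new, unique, unknown or untested is made for them only; others in the source may bear on it.

Compound 1 `CCC(C)(C)c1ccc(S(=O)(=O)Nc2ncnc(OCCOc3ncc(Br)cn3)c2-c2ccc(C)cc2)cc1`; compound 2 `CCc1ccc(-c2c(NS(=O)(=O)c3ccc(C(C)(C)C)cc3)ncnc2OCCOc2ncc(SC)cn2)cc1`.

In an assay on cells (Endothelial cell) for binding affinity to Endothelin-1 receptor (Sus scrofa) (a higher number here means a weaker inhibitor, a lower number a stronger inhibitor), compound 1 gives < 0.001 nM, which is a limit of the assay and not a number. In this assay, among the measured compounds shown here, compound 2 gives 0.013 nM, the only plain number recorded so far. Compound 3 `CSc1cnc(OCCOc2ncnc(NS(=O)(=O)c3ccc(C(C)(C)C)cc3)c2-c2ccco2)nc1` has not yet been measured; it differs from compound 2 by furan-2-yl in place of 4-ethylphenyl on an aromatic carbon. For the measured compounds named here, no measured pair shows how such a change acts in this assay. The expected step is a 3.8-fold higher number from compound 2 to compound 3 (0.59 log units; beyond the scatter), a modest loss of potency. Compound 3 is therefore estimated at 0.05 nM, with a range from 0.01 nM to 0.3 nM.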

Compound 3, half-maximal inhibitory concentration: 2.9 nM
For compound 3 the middle estimate is 58-fold (1.76 log units) below the measured one; measured number above the stated range.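

Among the compounds shown here, this is the first step that can be read at this aromatic carbon, and it shows that the position matters a great deal. In this assay, furan-2-yl in place of 4-ethylphenyl gives a 220-fold higher number from compound 2 to compound 3 (2.35 log units; beyond the scatter). Exchanging the six-membered carbon ring and its ethyl group for a five-membered ring with one oxygen is therefore far from neutral here. Whether the ring, its oxygen or the lost ethyl group accounts for the change stays open, and a plain phenyl or a thiophen-2-yl group would help separate them. Gains beyond compound 2 may also be hard to size, as one value is a limit and not a number: the limit of < 0.001 nM in this assay, at which 1 of the 3 values shown sits.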